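The source may report more compounds than this note shows. Statements on the series, on what has been measured and on what is new or still open speak of the compounds shown alone.

The series shares a chain ending in a phenyl group, joined through an amide to a five-membered thiazolidinone-type core, and the compounds differ in what sits on the ring nitrogen and in the ring that links core and amide. Compound 1 `COc1ccccc1N1C(=O)CSC1C(=O)NCCCCc1ccccc1` has no linking ring at all. In a functional assay on HOS-TE85 cells (Homo sapiens) for inhibition, read by CCK-8 assay, with a stated time of 72 h (on this read-out higher numbers stand for weaker inhibition and lower numbers for stronger inhibition), compound 1 gives only a limit, > 1000 nM. Compound 2 `COc1ccccc1N1C(=O)CSC1c1cc(C(=O)NCCCCc2ccccc2)cc(C2CC2)c1` carries a methoxyphenyl on the ring nitrogen and a cyclopropyl on the linking ring, and in this assay compound 2 gives 23.5 nM. Compound 3 `CC(C)(C)c1conc1N1C(=O)CSC1c1cccc(C(=O)NCCCCc2ccccc2)c1` keeps the linking ring but bears a different group on the ring nitrogen. In this assay compound 3 gives only a limit, > 1000 nM, so compound 3 stands at the limit of > 1000 nM in this assay, at which 2 of the 3 values shown sit, and not among the measured numbers. Compound 4 `O=C(NCCCCc1ccccc1)c1cccc(C2SCC(=O)N2c2ccccn2)c1` differs from compound 3 in one place: a group of 6 heavy atoms (5 carbon, 1 nitrogen; one six-membered aromatic ring with 1 hetero atom) in place of a group of 9 heavy atoms (7 carbon, 1 nitrogen, 1 oxygen; one five-membered aromatic ring with 2 hetero atoms), on an amide-type nitrogen in a ring. Among the compounds with values here, no single-change step between measured compounds is available to set the size of this move. Compound 3 gives only a limit; from there any change in this assay can only appear as stronger inhibition or as no change. Compound 2 shows that an aromatic group on the ring nitrogen is compatible with 23.5 nM. The step of an at least 3.3-fold lower number from compound 3 to compound 4 (0.52 log units; beyond the scatter) is therefore expected to point toward stronger inhibition, with wide uncertainty. Compound 4 is estimated at 300 nM, between 40 nM and 2000 nM.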

Compound 4, half-maximal inhibitory concentration: 19.7 nM
Compound 4: middle estimate off by 15-fold (1.18 log units), on the high side; measured number outside the range, below it.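

In this assay, putting pyridin-2-yl in place of the five-membered aromatic group on the amide-type nitrogen in the ring gives an at least 50-fold lower number from compound 3 to compound 4 (1.70 log units; beyond the scatter). Within the data shown here, the earlier compounds offered no single-change step, so this is the first sign that the group at this position alone can move the read-out beyond the scatter, and that the choice of group here can separate a compound at the limit of the assay from one with a measured number. Compound 3 gives only a limit, so the step has a floor but no measured size: the limit of > 1000 nM in this assay, at which 2 of the 4 values shown sit.

The compounds shown leave open whether the nitrogen of the pyridin-2-yl ring matters at all, which a plain phenyl group at this position would test against compound 4, and how a small group such as methyl would compare there. They also leave open whether a cyclopropyl group on the linking ring, taken alone, would shift the value of compound 4 in either direction.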